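Adding a second trifluoromethyl to compound 1

A few compounds are considered here, and "the series" means these few. Any claim that something is new, unique, unknown or untested is made for them only; others in the source may bear on it.

Compound 1 `CN(C(=O)NC(=O)c1ccc(Cl)cc1Cl)c1nc(C(F)(F)F)c(C(=O)N/N=C/c2cccc(C(F)(F)F)c2)s1` gives 11.2 ug/mL in a functional assay on HepG2 cells (Homo sapiens) for inhibition, read by MTT assay, with a stated time of 72 h (a higher number here means a weaker inhibitor, a lower number a stronger inhibitor), the lowest of the three numbers measured. Compound 2 `CN(C(=O)NC(=O)c1ccc(Cl)cc1Cl)c1nc(C(F)(F)F)c(C(=O)N/N=C/c2ccc(C(F)(F)F)cc2)s1` gives 12.4 ug/mL in this assay, and compound 3 `CN(C(=O)NC(=O)c1c(F)cccc1F)c1nc(C(F)(F)F)c(C(=O)N/N=C/c2cccc(C(F)(F)F)c2)s1` gives 27.9 ug/mL. Compound 4 `CN(C(=O)NC(=O)c1ccc(Cl)cc1Cl)c1nc(C(F)(F)F)c(C(=O)N/N=C/c2cc(C(F)(F)F)cc(C(F)(F)F)c2)s1` carries trifluoromethyl in place of hydrogen on an aromatic carbon, trifluoromethyl in place of hydrogen on an aromatic carbon, meta to a trifluoromethyl group. The step that bears on it is a 1.1-fold higher number from compound 1 to compound 2 (0.04 log units; within the scatter), which altered the same trifluoromethyl-bearing ring and stayed within the scatter; a 2.5-fold higher number from compound 1 to compound 3 (0.40 log units; beyond the scatter) concerns the other end of the molecule. A second trifluoromethyl on that ring is therefore expected to give a step of a 1.0-fold higher number from compound 1 to compound 4 (0.01 log units; within the scatter), within the scatter. Compound 4 is estimated at 11.5 ug/mL, with a range of 6 ug/mL to 23 ug/mL.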

Compound 4, half-maximal inhibitory concentration: > 100 ug/mL
Compound 4 was reported as a limit; the forecaster's own chance of this, stated with the estimate: 5%; middle value at least 8.6-fold (0.93 log units) from the limit.
By their numbers in this assay, from the lowest: compounds 1 and 2 (each within the scatter of the next); then compound 3. At a limit, above all of these: compound 4.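

On the trifluoromethyl-bearing ring, shifting the group left the number within the scatter, but adding a second trifluoromethyl, meta to a trifluoromethyl group, gives an at least 8.9-fold higher number from compound 1 to compound 4 (0.95 log units; beyond the scatter). This ring is therefore not indifferent to change, and the added group counts for more here than the shift did. In this assay compound 4 stands at a limit and not at a number: the limit of > 100 ug/mL in this assay, at which 1 of the 4 values shown sits.

Open, on these data alone, is whether the loss belongs to trifluoromethyl itself or to any added group at this place. A fluorine, a methoxy or an amine there would separate the two.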